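From thiophen-2-yl to 5-(methoxymethyl)furan-2-yl in compound 4

This account rests on a few compounds, and the source may have more. Where it says the series, first, only, none or still open, it means among the compounds named here.

- compound 1 `O=c1[nH]/c(=C\c2cccc(Oc3ccc(F)cc3)c2)c(=O)[nH]/c1=C\c1cccnc1` gives > 1000 nM as a limit
- compound 2 `O=c1[nH]/c(=C\c2ccco2)c(=O)[nH]/c1=C\c1cccc(Oc2ccc(F)cc2)c1` gives 155 nM as a number
- compound 3 `O=c1[nH]/c(=C\c2cccs2)c(=O)[nH]/c1=C\c1cccc(Oc2ccc(F)cc2)c1` gives > 1000 nM as a limit

In a functional assay on NCI-H460 cells (Homo sapiens) for cytotoxicity, read by MTT assay, with a stated time of 72 h (on this read-out higher numbers stand for weaker inhibition and lower numbers for stronger inhibition), compound 3 gives > 1000 nM as a limit of the assay and not a number. Compound 3 stands at the limit of > 1000 nM in this assay, at which 2 of the 3 values shown sit, and has no exact number.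

Compound 4 `COCc1ccc(/C=c2\[nH]c(=O)/c(=C/c3cccc(Oc4ccc(F)cc4)c3)[nH]c2=O)o1` differs from compound 3 in one place (5-(methoxymethyl)furan-2-yl in place of thiophen-2-yl on a double-bonded chain carbon bound to an aromatic carbon), with 5-(methoxymethyl)furan-2-yl in place of thiophen-2-yl on a double-bonded chain carbon bound to an aromatic carbon.

The closest measured evidence is an at least 6.4-fold higher number from compound 2 to compound 3 (0.80 log units; beyond the scatter) when thiophen-2-yl takes the place of furan-2-yl. Read backwards, that step favours a furan-2-yl ring at this place. A second step points the same way, with an at least 6.4-fold lower number from compound 1 to compound 2 (0.80 log units; beyond the scatter) when furan-2-yl replaces pyridin-3-yl. The third step, a step that the two limits leave unreadable from compound 1 to compound 3, cannot be sized. Going by the values given here, no measured compound carries the methoxymethyl group, so its contribution is open and the uncertainty is wide.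

A lower number than the limit of compound 3 is therefore expected in this assay, and the expected move is an at least 4.0-fold lower number from compound 3 to compound 4 (0.60 log units; beyond the scatter) on this estimate. For compound 4 the estimate is 250 nM with 60 nM to 1000 nM as the expected range.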

Compound 4, half-maximal inhibitory concentration: 14 nM
Compound 4: middle estimate off by 18-fold (1.25 log units), on the high side, outside the stated range (below it).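

In this assay, going by these compounds alone, methoxymethyl in place of hydrogen on an aromatic carbon gives an 11-fold lower number from compound 2 to compound 4 (1.04 log units; beyond the scatter), so the choice of ring is not all that counts at this position: a group added to the furan-2-yl ring also moves the result by a large step, which the earlier compounds could not show. The full change from thiophen-2-yl to 5-(methoxymethyl)furan-2-yl gives an at least 71-fold lower number from compound 3 to compound 4 (1.85 log units; beyond the scatter), and the change from pyridin-3-yl to the same group gives an at least 71-fold lower number from compound 1 to compound 4 (1.85 log units; beyond the scatter). Both of these steps are minimum sizes, because compound 1 and compound 3 each rest on a limit and not on a number: the limit of > 1000 nM in this assay, at which 2 of the 4 values shown sit.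

Only one group on the furan-2-yl ring is shown here, so it stays open whether a simple ethyl chain, a hydroxymethyl group or an aminomethyl group would give a similar step. On these data alone, it also stays open whether methoxymethyl on a thiophen-2-yl ring would bring the same change, and the step between compound 1 and compound 3 cannot be read.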